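Alkynyl Uracil Phthalimides: Shortening the Alkyne Chain

A few compounds are considered here, and "the series" means these few. Any claim that something is new, unique, unknown or untested is made for them only; others in the source may bear on it.

Compound 1 `O=C1c2ccccc2C(=O)N1C/C=C\Cn1cc(C#Cc2ccc(Br)cc2)c(=O)[nH]c1=O` carries an aryl alkyne on the shared core, and in a functional assay on CCRF-CEM cells (Homo sapiens) for antiproliferative activity, read by MTT assay, with a stated time of 3 days (on this read-out lower numbers stand for stronger inhibition and higher numbers for weaker inhibition), compound 1 gives 80000 nM. Compound 2 `CCCCCC#Cc1cn(C/C=C/CN2C(=O)c3ccccc3C2=O)c(=O)[nH]c1=O` carries a hexynyl chain instead. In this assay compound 2 reaches only a limit of the assay, > 500000 nM. Compound 2 thus sits at the limit of > 500000 nM in this assay, at which 1 of the 2 values shown sits, and no number places it against compound 1. Compound 3 `CCCCC#Cc1cn(C/C=C/CN2C(=O)c3ccccc3C2=O)c(=O)[nH]c1=O` is unmeasured and differs from compound 2 by hydrogen in place of methyl on a saturated chain carbon, four bonds along the chain from a triple-bonded carbon. For the measured compounds named here, no measured step covers this change; the step from compound 2 to compound 3 is expected to be small, a step that the limit leaves unreadable from compound 2 to compound 3, not beyond the scatter. Compound 3 is estimated at 600000 nM, within 150000 nM to 2000000 nM.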

Compound 3, half-maximal inhibitory concentration: 192000 nM
The estimate for compound 3 lay 3.1-fold (0.49 log units) above the measured number; low and high end bracket the measured number.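

For the compounds shown here, this is the first readable change on the saturated chain: hydrogen in place of methyl, four bonds along the chain from a triple-bonded carbon, gives an at least 2.6-fold lower number from compound 2 to compound 3 (0.41 log units; beyond the scatter) in this assay. This position therefore responds to the loss of a single carbon. The step is only a lower bound, since compound 2 stands at a limit of the assay: the limit of > 500000 nM in this assay, at which 1 of the 3 values shown sits.

Open, from the compounds shown here alone, is whether a propyl chain in this position continues the direction, and what an amine or a carboxylic acid in place of that methyl would do. Compound 1 differs from compound 3 in more than one place, so the aryl alkyne and the alkyl chain stay unranked.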